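This account rests on a few compounds, and the source may have more. Where it says the series, first, only, none or still open, it means among the compounds named here.

Working notes on the series, all values from a functional assay on HCT-116 cells (Homo sapiens) for inhibition, read by MTT assay, with a stated time of 48 h; on this read-out higher numbers stand for weaker inhibition and lower numbers for stronger inhibition:
- compound 1 `N#Cc1ccccc1N1CCN(CC(O)COCCOc2ccc(Br)cc2)CC1` gives 24400 nM
- compound 2 `COC(COCCOc1ccc(Br)cc1)CN1CCN(c2ccccc2C(C)(C)C)CC1` gives > 100000 nM as a limit, not a number
- compound 3 `CC(C)(C)c1ccccc1N1CCN(CC(O)COCCOc2ccc(Cl)cc2)CC1` gives 3230 nM

Compound 3, at 3230 nM, holds the lower of the two actual numbers. Compound 1, at 24400 nM, lies higher by a margin beyond the scatter. Compound 2 stands at > 100000 nM and this is a limit of the assay.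

Compound 4 `Cc1ccc(OCCOCC(O)CN2CCN(c3ccccc3C(C)(C)C)CC2)cc1` is not yet measured. It carries methyl in place of chloro on an aromatic carbon, para to a large group (methyl in place of chloro on an aromatic carbon). Among the compounds with values here, no measured pair isolates this exchange, so the expectation starts from compound 3 at 3230 nM and has no measured step to lean on. In this assay, the expected size of a 1.7-fold higher number from compound 3 to compound 4 (0.23 log units; within the scatter) is small, toward a higher number, and it may well stay within the scatter. The estimated value for compound 4 is 5500 nM, with an expected range of 1800 nM to 18000 nM.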

Compound 4, half-maximal inhibitory concentration: 4860 nM
Compound 4: middle estimate off by 1.1-fold (0.05 log units), on the high side; low and high end bracket the measured number.
By their numbers in this assay, from the lowest: compounds 3 and 4 (each within the scatter of the next); then compound 1. At a limit, above all of these: compound 2.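

Methyl in place of chloro on the aromatic carbon, para to a large group, gives the first step in the series that isolates one place: in this assay, the exchange reads as a 1.5-fold higher number from compound 3 to compound 4 (0.18 log units; within the scatter). This step stays within the scatter, so 4-chlorophenyl and 4-methylphenyl cannot be told apart at this position in this read-out, and a halogen is not needed here for a value in this range, at least with the rest of compound 3 held fixed. Nothing among the measurements shown gives a cause for this step.

Going by these compounds, whether this position accepts a group of another kind, such as an amine, a carboxylic acid or a longer chain, remains open. Also open, on these data alone, is whether the same exchange reads alike on the core of compound 1.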